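The compounds below may be only part of what the source reports. "The series", "measured", "known", "first", "only" and "open" are said of these compounds alone.

Two compounds share a core and differ in the substituents on a benzyl ring. Compound 1, `CC(C)Cn1c(=O)c2nc(-c3cnn(Cc4cccc(C(F)(F)F)c4)c3)[nH]c2n(CC(C)C)c1=O`, carries a trifluoromethyl group on that ring, and in an in vitro assay on HEK293 cells for displacement of a labelled ligand from adenosine receptor A2b (Homo sapiens) (a higher number here means a weaker inhibitor, a lower number a stronger inhibitor), compound 1 gives 300 nM. Compound 2, `CCCn1c(=O)c2nc(-c3cnn(Cc4ccc(OC)c(C(F)(F)F)c4)c3)[nH]c2n(CCC)c1=O`, adds a methoxy group and shortens the two chains on the core; in this assay compound 2 gives 410 nM. Of the two numbers, that of compound 2 is the higher one, but the gap to compound 1 lies within the usual scatter of such measurements, so the two cannot be told apart.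

The next compound, compound 3, `CCCn1c(=O)c2nc(-c3cnn(Cc4ccc(F)c(C(F)(F)F)c4)c3)[nH]c2n(CCC)c1=O`, differs from compound 2 in one place: fluoro in place of methoxy on an aromatic carbon. For the measured compounds named here, no pair in hand shows what this exchange does to binding, and the two numbers so far sit close together. The expectation is therefore a step of about a 1.2-fold lower number from compound 2 to compound 3 (0.07 log units; within the scatter) from compound 2 to compound 3, which is none beyond the scatter. For compound 3 the estimated inhibition constant in this assay is 350 nM, with a likely range from 150 nM to 800 nM.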

Compound 3, inhibition constant: 640 nM
Beside the measured number, compound 3's estimate is 1.8-fold (0.26 log units) below it; the measured number falls inside the stated range.
By their numbers in this assay, from the lowest: compounds 1, 2 and 3 (each within the scatter of the next, the first and the last beyond it).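

For the compounds shown here, the first matched pair at this position is the exchange of methoxy for fluoro, on the aromatic carbon ortho to a trifluoromethyl group and para to a large group, which gives a 1.6-fold higher number from compound 2 to compound 3 (0.19 log units; within the scatter) in this assay and so leaves the two compounds indistinguishable. Here a group of 2 heavy atoms with 1 hydrogen-bond acceptor gives way to a single fluorine atom with no hydrogen-bond acceptor, and binding to the receptor shows no change that can be separated from the ordinary spread of repeated measurements. This one pair therefore gives no sign that this position depends on which of these two groups it carries, although a single pair cannot establish a general rule.

The compounds shown leave open whether a much different group at this position, such as an amine, a carboxylic acid or a longer chain in place of methoxy, would also leave the number within the scatter. On these data alone, it is also open whether the same exchange would read alike on a core carrying the two chains of compound 1, and no measurement in hand bears on why this exchange behaves as it does.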